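A few compounds are considered here, and "the series" means these few. Any claim that something is new, unique, unknown or untested is made for them only; others in the source may bear on it.

Measured compounds:
compound 1 `Cc1nc(N)sc1CCCN/C(N)=N/C(=O)N[C@@H](C)c1ccccc1` — 51.3 nM
compound 2 `Cc1nc(N)sc1CCCN/C(N)=N/C(=S)N[C@@H](C)c1ccccc1` — 339 nM
compound 3 `Cc1nc(N)sc1CCCN/C(N)=N/C(=O)NC(C)c1ccc(OC(F)(F)F)cc1` — 126 nM

Measured in an assay on membranes from Sf9 cells for displacement of a labelled ligand from histamine H2 receptor (Homo sapiens), read by scintillation counting, with a stated time of 60 min (a lower number here means a stronger inhibitor, a higher number a weaker inhibitor), compound 1 has the lowest number of the three. The nearest is compound 3 at 126 nM, a gap beyond the scatter, and compound 2 at 339 nM stands furthest, also beyond the scatter. Within this small set compound 1 is therefore the strongest inhibitor.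

Compound 4 `CCCCCNC(=O)/N=C(\N)NCCCc1sc(N)nc1C` is not yet measured. Relative to compound 1 the change is pentyl in place of 1-phenylethyl on an amide-type nitrogen. Among the compounds with values here, no pair of measured compounds shows an exchange of this kind, so the size of the step can only be judged from the series as it stands. The one measured variation at this nitrogen, compound 3 set against compound 1, carries the number upward; a pentyl chain with no ring in place of a group that carries a ring is expected to carry it upward as well, by a moderate step. Compound 4 is estimated at 160 nM in this assay, within a range of 50 nM to 500 nM. The expected step is a 3.1-fold higher number from compound 1 to compound 4 (0.49 log units; beyond the scatter), beyond the usual scatter.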

Compound 4, inhibition constant: 4.47 nM
Compound 4: middle estimate off by 36-fold (1.55 log units), on the high side; the measured number lies below the stated range.
By their numbers in this assay, from the lowest: compound 4; then compound 1; then compound 3; then compound 2.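

At this amide-type nitrogen, an aromatic ring is not needed for a low number in this assay: pentyl in place of 1-phenylethyl gives an 11-fold lower number from compound 1 to compound 4 (1.06 log units; beyond the scatter) and ranks as a large step. The exchange removes the six-membered aromatic ring, the defined stereocentre and the branched attachment together, and this single step does not assign its size to any one of them. No measurement shown here accounts for the size of this step.

Still open, from the compounds shown here alone, is whether the low number depends on chain length, which butyl or hexyl at the same nitrogen would test. A cyclohexyl group or an unbranched 2-phenylethyl group there would help separate the loss of the aromatic ring from the loss of the branch.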